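The compounds below may be only part of what the source reports. "The series", "measured", "known", "first", "only" and "open" are said of these compounds alone.

Three compounds share one core and differ at its two ends. Compound 1 `CC(C)(C)OC(=O)N1CCC2(CC1)CC(CCCOc1ccc(S(C)(=O)=O)cc1)C2` gives 14 nM in a functional assay on cells for agonist activity at Glucose-dependent insulinotropic receptor (Homo sapiens), read by HTRF and cAMP accumulation, with a stated time of 30 min; on this read-out higher numbers stand for an effect only at larger amounts of compound and lower numbers for an effect already at smaller amounts. Compound 2 `CC1(OC(=O)N2CCC3(CC2)CC(CCCOc2ccc(S(C)(=O)=O)c(F)c2)C3)CC1` gives 13 nM in this assay. Compound 3 `CC(C)OC(=O)N1CCC2(CC1)CC(CCCOc1ccc(C(=O)NC3CC3)c(F)c1)C2` gives 8 nM in this assay, which is the lowest of the three numbers, though both other values sit within the usual scatter of it, so no order among the three can be read from these figures. Compound 4 `CC(C)OC(=O)N1CCC2(CC1)CC(CCCOc1ccc(C(=O)N3CCC3)c(F)c1)C2` has not yet been measured in this assay. It differs from compound 3 in a single place: azetidin-1-yl in place of cyclopropylamino on a carbonyl carbon. The same atoms are present, joined differently. Among the compounds with values here, no measured pair among the three compounds shows this kind of change, so there is no step to lean on, and the expectation rests on the general observation that the three measured values lie close together. For compound 4 the expected step is small, if any, and not clearly beyond the scatter, estimated as a 1.9-fold higher number from compound 3 to compound 4 (0.27 log units; within the scatter). Compound 4 is therefore expected to give about 15 nM in this assay, within a range of 5 nM to 45 nM.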

Compound 4, half-maximal effective concentration in the Glucose-dependent insulinotropic receptor assay: 34 nM
Compound 4: middle estimate off by 2.3-fold (0.36 log units), on the low side; the measured number falls inside the stated range.
By their numbers in the Glucose-dependent insulinotropic receptor assay, from the lowest: compounds 3, 2 and 1 (each within the scatter of the next); then compound 4.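

This is the first step among these compounds that lies beyond the scatter: in the Glucose-dependent insulinotropic receptor assay, putting azetidin-1-yl in place of cyclopropylamino on a carbonyl carbon gives a 4.3-fold higher number from compound 3 to compound 4 (0.63 log units; beyond the scatter). The three earlier values lie within the scatter of one another, so they could not show that this position responds to a change, here one that keeps the same atoms but removes the amide hydrogen. In a physicochemical assay for solubility, read by HPLC, in phosphate buffer, with a stated time of 24 h, at pH 6.8 (on this read-out lower numbers stand for lower solubility and higher numbers for higher solubility), compound 3 gives 0.21 ug/mL and compound 4 gives 3.43 ug/mL, so the same change moves the result in a favourable direction and the gain in solubility comes with a loss in the Glucose-dependent insulinotropic receptor assay: the measured solubility of compound 3, 0.21 ug/mL, and of compound 4, 3.43 ug/mL, a 16-fold higher number (1.21 log units; beyond the scatter)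

This single pair cannot separate the loss of the amide hydrogen from the change of ring. Going by these compounds, how a pyrrolidin-1-yl ring or a dimethylamino group on the same carbonyl carbon would behave in these two read-outs remains open.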